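From Acetyl to 3-Methoxyphenyl on the Shared Core

The source may report more compounds than this note shows. Statements on the series, on what has been measured and on what is new or still open speak of the compounds shown alone.

Compound 1 `O=C(Nc1ccc2nc(NC(=O)C3CCCCC3)sc2c1)c1ccccc1Cl`: 0.025 ug/mL
Compound 2 `O=C(Nc1nc2ccc(N/C(S)=N/c3ccccc3OC(F)(F)F)cc2s1)C1CCCCC1`: 2.3 ug/mL
Compound 3 `CC(=O)Nc1nc2ccc(NC(=O)c3c(Cl)cccc3Cl)cc2s1`: 0.6 ug/mL

In a functional assay on WI-38 VA13 cells (Homo sapiens) for cytotoxicity (a higher number here means that more compound is needed for the effect, a lower number that less compound is needed), compound 3 stands second highest of the three numbers. Compound 2 sits higher, beyond the scatter, and compound 1 sits lower, also beyond the scatter, so compound 3 occupies the middle of the measured range.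

Compound 4 `COc1cccc(Nc2nc3ccc(NC(=O)c4c(Cl)cccc4Cl)cc3s2)c1` has not yet been measured in this assay. It differs from compound 3 in one place: 3-methoxyphenyl in place of acetyl on a nitrogen on an aromatic ring. Among the measured compounds shown here, no pair of measured compounds isolates this change, so its effect rests on expectation alone. A modest step downward is expected, a 2.0-fold lower number from compound 3 to compound 4 (0.30 log units; within the scatter), since compound 1, which carries a larger group on the same nitrogen, gives 0.025 ug/mL. Compound 4 is therefore estimated at 0.3 ug/mL, with a range from 0.06 ug/mL to 1.5 ug/mL.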

Compound 4, half-maximal effective concentration: > 7.2 ug/mL
Compound 4 was reported as a limit; the forecaster's own chance of this, stated with the estimate: 5%; middle value at least 24-fold (1.38 log units) away from the limit.
By their numbers in this assay, from the lowest: compound 1; then compound 3; then compound 2. At a limit, above all of these: compound 4.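

In this assay, this nitrogen proves sensitive to what it carries, since 3-methoxyphenyl in place of acetyl gives an at least 12-fold higher number from compound 3 to compound 4 (1.07 log units; beyond the scatter). Compound 4 gives > 7.2 ug/mL, which is a limit of the assay and not a number: the limit of > 7.2 ug/mL in this assay, at which 1 of the 4 values shown sits.

The compounds shown leave open whether the step follows from losing the acetyl carbonyl or from gaining the aromatic ring, as acetamido gives way to (3-methoxyphenyl)amino in a single change. A benzoyl group or an unsubstituted phenyl on the same nitrogen would separate the two.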